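A Group Removed Twice from the Shared Core

The source may report more compounds than this note shows. Statements on the series, on what has been measured and on what is new or still open speak of the compounds shown alone.

Compound 1, `CN(C(=O)NC(=O)c1ccccc1F)c1nc(C(F)(F)F)c(C(=O)N/N=C/c2ccccc2C(F)(F)F)s1`, in a functional assay on MCF7 cells (Homo sapiens) for inhibition, read by MTT assay, with a stated time of 72 h (on this read-out higher numbers stand for weaker inhibition and lower numbers for stronger inhibition), gives 12.2 ug/mL.
Compound 3, `CN(C(=O)NC(=O)c1ccccc1F)c1nc(C(F)(F)F)c(C(=O)N/N=C/c2ccc(C(F)(F)F)cc2)s1`, in this assay gives 4.98 ug/mL.
Compound 2, `CNc1nc(C(F)(F)F)c(C(=O)N/N=C/c2ccccc2C(F)(F)F)s1`, in this assay gives only a limit of the assay, > 100 ug/mL.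

Compound 3 differs from compound 1 by 4-(trifluoromethyl)phenyl in place of 2-(trifluoromethyl)phenyl on a carbon with a double bond to nitrogen; this gave a 2.4-fold lower number from compound 1 to compound 3 (0.39 log units; beyond the scatter). Compound 2 differs from compound 1 by hydrogen in place of ((2-fluorophenyl)carbonyl)carbamoyl on a nitrogen on an aromatic ring; this gave an at least 8.1-fold higher number from compound 1 to compound 2 (0.91 log units; beyond the scatter), a step whose size is known only as a floor because compound 2 sits at the limit of > 100 ug/mL in this assay, at which 1 of the 3 values shown sits.

Compound 4, `CNc1nc(C(F)(F)F)c(C(=O)N/N=C/c2ccc(C(F)(F)F)cc2)s1`, is not yet measured. It differs from compound 3 by hydrogen in place of ((2-fluorophenyl)carbonyl)carbamoyl on a nitrogen on an aromatic ring, the same change as from compound 1 to compound 2. Repeating that step from compound 3, compound 4 is expected to show a 12-fold higher number from compound 3 to compound 4 (1.08 log units; beyond the scatter) in this assay. The estimated value for compound 4 is 60 ug/mL, between 20 ug/mL and 150 ug/mL, with a real chance that only a limit is reported.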

Compound 4, half-maximal inhibitory concentration: > 100 ug/mL
Compound 4 was reported as a limit (the forecaster's own chance of this, stated with the estimate: 55%); at least 1.6-fold (0.22 log units) between middle value and limit.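

Taking away the ((2-fluorophenyl)carbonyl)carbamoyl group from the second core gives, in this assay, an at least 20-fold higher number from compound 3 to compound 4 (1.30 log units; beyond the scatter). The change therefore weakens inhibition on both cores, which is the same direction each time: the same change on two cores in this assay, an at least 8.1-fold higher number (0.91 log units; beyond the scatter) from compound 1 to compound 2 and an at least 20-fold higher number (1.30 log units; beyond the scatter) from compound 3 to compound 4; the limit leaves it open whether they differ What this does not show is how large the loss really is on either core, as compound 2 and compound 4 are both reported only as a limit of the assay: the limit of > 100 ug/mL in this assay, at which 2 of the 4 values shown sit.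

On these data alone, on that nitrogen, only the whole group and hydrogen are compared, so it stays open which part of the group matters. A smaller acetyl or plain carbamoyl group in the same place would test this.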